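Working notes: hydroxymethyl step from compound 1

The source may hold more compounds than are shown below. What is called first, only, known or untested is meant among the compounds shown, and "the series" means these compounds.

- compound 1 `C=CCc1cc(O)c(O)c(CN2CCC(C)CC2)c1`: 91.1%
- compound 2 `C=CCc1ccc(OCc2cn(-c3ccccc3Cl)nn2)c(O)c1`: 38.7%

In a functional assay on HL-60 cells (Homo sapiens) for inhibition, read by MTT assay, with a stated time of 72 h, tested at 30 uM (on this read-out lower numbers stand for less inhibition of growth and higher numbers for more inhibition of growth at the one concentration tested), compound 1 reaches 91.1%, the higher of the two numbers, and the gap down to compound 2 lies beyond the usual scatter. The next compound to be read is compound 3 `C=CCc1cc(O)c(O)c(CN2CCC(CO)CC2)c1`, which keeps the core of compound 1 and differs in one place: hydroxy in place of hydrogen on a saturated chain carbon bound to a saturated ring carbon. The same difference reads as methyl to hydroxymethyl. Among the compounds with values here, no measured pair in this small set shows this change, so the expectation stays loose. With compound 1 at 91.1%, little room remains upward, so a moderate downward step is expected in this assay, one that may end close to the scatter. The estimated change is a number 13.1 percentage points lower from compound 1 to compound 3 (beyond the scatter). For compound 3 the expected value is 78%, with an estimated range of 55% to 97%.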

Compound 3, percent growth inhibition at one concentration: 37.7%
Estimate against measurement, compound 3: 40.3 percentage points above; the measured number lies below the stated range.
By their numbers in this assay, from the lowest: compounds 3 and 2 (each within the scatter of the next); then compound 1.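

In this assay, the methyl to hydroxymethyl change gives a number 53.4 percentage points lower from compound 1 to compound 3 (beyond the scatter), a large step from one added hydroxy on a saturated chain carbon bound to a saturated ring carbon. Within the data shown here, this is the first pair to differ in one place, and it shows that the read-out at this position responds strongly to a single heavy atom. Nothing shown here accounts for the size of this step.

As far as these compounds go, whether the drop belongs to the hydroxy itself or would come with other groups at this place remains open; a methoxymethyl, an aminomethyl, a carboxylic acid or a longer chain would each give a further point of comparison. A single pair also leaves open whether the same change would give a step of this size on another compound of the series.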